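Swapping an aryl group for methyl in a cytotoxic series

The compounds below may be only part of what the source reports. "The series", "measured", "known", "first", "only" and "open" are said of these compounds alone.

Compound 1 `COc1cc(COCc2cn(Cc3cc(C)cnc3Cl)nn2)cc(OC)c1OC`: 41900 nM
Compound 2 `COc1cc(-c2cc(COCc3cn(Cc4cc(-c5ccccc5)cnc4Cl)nn3)on2)cc(OC)c1OC`: 112000 nM
Compound 3 `COc1cc(-c2cc(COCc3cn(Cc4cc(-c5ccc(C)cc5)cnc4Cl)nn3)on2)cc(OC)c1OC`: 30600 nM

These numbers come from a functional assay on A549 cells (Homo sapiens) for cytotoxicity, read by MTT assay, with a stated time of 48 h; a higher number here means a weaker inhibitor, a lower number a stronger inhibitor. Compound 3, at 30600 nM, cannot be told apart from compound 1 within the usual scatter, while compound 2 gives a clearly higher number.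

Compound 4 `COc1cc(-c2cc(COCc3cn(Cc4cc(C)cnc4Cl)nn3)on2)cc(OC)c1OC` is the next case, with methyl in place of 4-methylphenyl on an aromatic carbon.

Among the measured compounds shown here, only one measured step bears directly on this group. Adding methyl in place of hydrogen on an aromatic carbon gave a 3.7-fold lower number from compound 2 to compound 3 (0.56 log units; beyond the scatter), a modest change. It shows that the outer part of this group can shift the number, but no measurement shows what removing the whole aromatic ring does. Compound 1 also carries methyl here, on a different remaining structure, and gives 41900 nM.

The expected step is a 1.5-fold higher number from compound 3 to compound 4 (0.17 log units; within the scatter), so no clear change is expected. For compound 4 the estimated value is 45000 nM, with an expected range of 15000 nM to 120000 nM.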

Compound 4, half-maximal inhibitory concentration: 256000 nM
Compound 4: middle estimate off by 5.7-fold (0.76 log units), on the low side; measured number above the stated range.
By their numbers in this assay, from the lowest: compounds 3 and 1 (each within the scatter of the next); then compound 2; then compound 4.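

In this assay, the aromatic ring at this position turns out to matter as a whole, not just its outer methyl: swapping 4-methylphenyl for methyl gives (an 8.4-fold higher number from compound 3 to compound 4 (0.92 log units; beyond the scatter)). Swapping plain phenyl for methyl points the same way, with (a 2.3-fold higher number from compound 2 to compound 4 (0.36 log units; beyond the scatter)), so on this shared core both aryl compounds give lower numbers than the methyl compound, and the larger step comes from the 4-methylphenyl compound. No measurement here explains why the ring makes this difference.

As far as these compounds go, with only methyl, phenyl and 4-methylphenyl to compare, it remains open whether an aromatic ring is specifically needed here or whether a longer alkyl chain could serve as well. From the compounds shown here alone, it is also open how an amine or a carboxylic acid would behave, either at this position or on the outer ring.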